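The compounds below may be only part of what the source reports. "The series", "measured", "known", "first", "only" and "open" are said of these compounds alone.

In a functional assay on HUVEC cells (Homo sapiens) for cytotoxicity (a lower number here means that less compound is needed, a higher number that more compound is needed for the effect), compound 1 `COC1=C(C)C(=O)/C(=C(O)/C=C/c2ccc(F)cc2)C(=O)C1(C)C` gives 2 ug/mL and compound 2 `COC1=C(C)C(=O)/C(=C(O)/C=C/c2ccccc2C)C(=O)C1(C)C` gives 2.3 ug/mL, which places compound 2 level with compound 1 within the scatter. Compound 3 `COC1=C(C)C(=O)/C(=C(O)/C=C/c2c(C)cccc2C)C(=O)C1(C)C` differs from compound 2 by methyl in place of hydrogen on an aromatic carbon, a methyl in place of hydrogen on an aromatic carbon that turns 2-methylphenyl into 2,6-dimethylphenyl. For the measured compounds named here, the only measured step, a 1.2-fold higher number from compound 1 to compound 2 (0.06 log units; within the scatter), has 2-methylphenyl in place of 4-fluorophenyl and stays within the scatter. It does not test this methyl directly, so no step beyond the scatter is expected in this assay. The estimated step is a 1.0-fold higher number from compound 2 to compound 3 (0.02 log units; within the scatter). Compound 3 is expected at 2.4 ug/mL, with an estimated range of 1 ug/mL to 5.5 ug/mL.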

Compound 3, concentration for half-maximal effect: 3 ug/mL
The estimate for compound 3 lay 1.3-fold (0.10 log units) below the measured number; measured number inside the range.
By their numbers in this assay, from the lowest: compounds 1, 2 and 3 (each within the scatter of the next).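

In this assay methyl in place of hydrogen on this aromatic carbon gives a 1.3-fold higher number from compound 2 to compound 3 (0.12 log units; within the scatter) and so the turn from 2-methylphenyl to 2,6-dimethylphenyl stays within the scatter. The wider swap from 4-fluorophenyl to 2,6-dimethylphenyl gives a 1.5-fold higher number from compound 1 to compound 3 (0.18 log units; within the scatter) and also stays within the scatter.

Still open, as far as these compounds go, is whether an amine, a carboxylic acid or a longer chain in place of this methyl would give a step beyond the scatter. No measurement at hand explains why these steps remain so small.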